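Amide Tail Change From Compound 2 to Compound 4

A few compounds are considered here, and "the series" means these few. Any claim that something is new, unique, unknown or untested is made for them only; others in the source may bear on it.

Measured compounds:
compound 1 `CCn1c(C(=O)N[C@@H](CC(=O)OC)C(=O)OC)ccc1C(CC)(CC)c1ccc(OCS(=O)(=O)c2ccccc2)c(C)c1` — 6490 nM
compound 2 `CCn1c(C(=O)NCCN)ccc1C(CC)(CC)c1ccc(OCS(=O)(=O)c2ccccc2)c(C)c1` — 6890 nM
compound 3 `CCN(CC)CCNC(=O)c1ccc(C(CC)(CC)c2ccc(OCS(=O)(=O)c3ccccc3)c(C)c2)n1CC` — 7130 nM

Three compounds share one core and differ only in the group on the amide-type nitrogen. In a functional assay on PC-3 cells (Homo sapiens) for antiproliferative activity, read by MTT assay, with a stated time of 24 h (a lower number here means a stronger inhibitor, a higher number a weaker inhibitor), compound 1 gives 6490 nM, compound 2 gives 6890 nM, and compound 3 gives 7130 nM. Compound 2 stands second highest of the three numbers; its nearest neighbour is compound 3, with a 1.0-fold higher number from compound 2 to compound 3 (0.01 log units; within the scatter), and its furthest is compound 1, with a 1.1-fold higher number from compound 1 to compound 2 (0.03 log units; within the scatter). Both steps lie within the scatter, so the three compounds cannot be ordered.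

Compound 4 `CCn1c(C(=O)NCC(=O)O)ccc1C(CC)(CC)c1ccc(OCS(=O)(=O)c2ccccc2)c(C)c1` is not yet measured. It differs from compound 2 by carboxy in place of aminomethyl on a saturated chain carbon bound to an amide-type nitrogen. Among the compounds with values here, the steps that bear on this are the two earlier changes at the same amide-type nitrogen, a 1.1-fold higher number from compound 1 to compound 2 (0.03 log units; within the scatter) and a 1.1-fold higher number from compound 1 to compound 3 (0.04 log units; within the scatter), neither of which moved the number beyond the scatter. Within the data shown here, no measured step introduces a carboxy group, so the expectation rests on those two. The author therefore expects no step beyond the scatter, a 1.0-fold higher number from compound 2 to compound 4 (0.01 log units; within the scatter), and estimates compound 4 at 7000 nM, within 3500 nM to 14000 nM.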

Compound 4, half-maximal inhibitory concentration: 30100 nM
Beside the measured number, compound 4's estimate is 4.3-fold (0.63 log units) below it; measured number above the stated range.
By their numbers in this assay, from the lowest: compounds 1, 2 and 3 (each within the scatter of the next); then compound 4.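

In this assay, within the data shown here, the group on the amide-type nitrogen does affect the number, as a 4.4-fold higher number from compound 2 to compound 4 (0.64 log units; beyond the scatter) and a 4.2-fold higher number from compound 3 to compound 4 (0.63 log units; beyond the scatter) and a 4.6-fold higher number from compound 1 to compound 4 (0.67 log units; beyond the scatter) all lie beyond the scatter, whereas the earlier steps among the first three compounds did not. Carboxymethyl is thus the only one of the four groups at this position that stands apart, while 2-aminoethyl, 2-(diethylamino)ethyl and 1,2-bis(methoxycarbonyl)ethyl cannot be ordered among themselves. Nothing available here accounts for this separation.

On these data alone, it remains open whether the higher number depends on the free carboxylic acid itself, which the methyl ester of the carboxymethyl group could test. A longer chain such as 2-carboxyethyl could likewise show whether the distance of the carboxy group from the amide-type nitrogen matters.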